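A few compounds are considered here, and "the series" means these few. Any claim that something is new, unique, unknown or untested is made for them only; others in the source may bear on it.

In a functional assay on HeLa cells (Homo sapiens) for cytotoxicity, read by MTT assay, with a stated time of 48 h (a higher number here means a weaker inhibitor, a lower number a stronger inhibitor), compound 1 `CCN(CC)c1ccc2cc(C(=O)c3ccc(N4CCN(C(=O)CN5CCN(C(=O)CCl)CC5)CC4)cc3)oc2c1` gives 5520 nM. Compound 2 `CCN(CC)c1ccc2cc(C(=O)c3ccc(N4CCN(C(=O)CN5CCN(Cc6ccc(/C=C/C(=O)OC)cc6)CC5)CC4)cc3)oc2c1` gives 3040 nM in this assay; the two numbers lie within the scatter of each other, so neither compound can be said to stand apart from the other. Compound 3 `CCOC(=O)CN1CCN(CC(=O)N2CCN(c3ccc(C(=O)c4cc5ccc(N(CC)CC)cc5o4)cc3)CC2)CC1` has not yet been measured; it differs from compound 2 by ethoxycarbonyl in place of 4-(2-(methoxycarbonyl)ethenyl)phenyl on a saturated chain carbon bound to an amine nitrogen in a ring. Among the measured compounds shown here, no measured pair shows a step of this kind, so nothing beyond these two values can be drawn on. The step of a 1.3-fold higher number from compound 2 to compound 3 (0.12 log units; within the scatter) is expected to stay within the scatter. Compound 3 is therefore estimated to give 4000 nM in this assay, between 1500 nM and 12000 nM.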

Compound 3, half-maximal inhibitory concentration: 22100 nM
Estimate against measurement, compound 3: 5.5-fold (0.74 log units) below, outside the stated range (above it).
By their numbers in this assay, from the lowest: compounds 2 and 1 (each within the scatter of the next); then compound 3.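

At this position, on a saturated chain carbon bound to an amine nitrogen in a ring, ethoxycarbonyl is not an equivalent of 4-(2-(methoxycarbonyl)ethenyl)phenyl: this assay shows a 7.3-fold higher number from compound 2 to compound 3 (0.86 log units; beyond the scatter). Compound 3 also stands apart from the chloroacetyl-bearing compound 1, where (ethoxycarbonyl)methyl in place of (chloromethyl)carbonyl on an amine nitrogen in a ring gives a 4.0-fold higher number from compound 1 to compound 3 (0.60 log units; beyond the scatter). Nothing measured here accounts for either step. From the compounds shown here alone, it remains open whether a plain phenyl or a carboxylic acid at this position would give a number closer to that of compound 2 or compound 3.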